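The source may report more compounds than this note shows. Statements on the series, on what has been measured and on what is new or still open speak of the compounds shown alone.

Working notes on the series, following the step from compound 2 to compound 4. Compound 1 `Cc1cc(C)cc(S(=O)(=O)c2c(C(=O)NC(c3ccc(Cl)cc3)C3CC3)[nH]c3ccc(Cl)cc23)c1`, compound 2 `Cc1cc(C)cc(S(=O)(=O)c2c(C(=O)NC(C)C(=O)NCc3ccncc3)[nH]c3ccc(Cl)cc23)c1` and compound 3 `Cc1cc(C)cc(S(=O)(=O)c2c(C(=O)NC(C)c3ccco3)[nH]c3ccc(Cl)cc23)c1` share one core and differ only in the group on the amide-type nitrogen. In an ADME assay on MT4 cells (Homo sapiens) for cytotoxicity, read by MTT assay (a lower number here means that less compound is tolerated, a higher number that more compound is tolerated), compound 1 gives only a limit, > 47300 nM. In this assay compound 3 also gives only a limit, > 54700 nM. For the measured compounds named here, compound 2 is the one member with a read number: in this assay compound 2 gives 19500 nM. Going by the values given here, compound 2 thus stands as the single read number among the three values.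

Both measured steps are bounded by these limits: an at least 2.4-fold lower number from compound 1 to compound 2 (0.38 log units; beyond the scatter), resting on (the limit of > 47300 nM in this assay, at which 1 of the 3 values shown sits), and an at least 2.8-fold higher number from compound 2 to compound 3 (0.44 log units; beyond the scatter), resting on (the limit of > 54700 nM in this assay, at which 1 of the 3 values shown sits). Their true sizes are therefore open; only their direction is known.

Compound 4 `Cc1cc(C)cc(S(=O)(=O)c2c(C(=O)NC(C)C(=O)NCCn3c(C)cnc3[N+](=O)[O-])[nH]c3ccc(Cl)cc23)c1` differs from compound 2 in one place: a group of 10 heavy atoms (5 carbon, 3 nitrogen, 2 oxygen; one five-membered aromatic ring with 2 hetero atoms) in place of a group of 6 heavy atoms (5 carbon, 1 nitrogen; one six-membered aromatic ring with 1 hetero atom), on a saturated chain carbon bound to an amide-type nitrogen. Neither measured step exchanges this group, and both move away from compound 2 in opposite directions, so they give no clear expected direction. The expected step is one that stays within the scatter, a 1.1-fold higher number from compound 2 to compound 4 (0.05 log units; within the scatter), with a real chance that only a limit is read. For compound 4 the estimate in this assay is 22000 nM, within 8000 nM to 55000 nM.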

Compound 4, half-maximal cytotoxic concentration: 16000 nM
For compound 4 the middle estimate is 1.4-fold (0.14 log units) above the measured one; measured number inside the range.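

On a saturated chain carbon bound to an amide-type nitrogen, a group of 10 heavy atoms, with one five-membered aromatic ring with 2 hetero atoms and 4 hydrogen-bond acceptors, replaces pyridin-4-yl, and the outcome in this assay is a 1.2-fold lower number from compound 2 to compound 4 (0.09 log units; within the scatter) for this change. For the compounds shown here, this is the one step with a read number on each side, and it shows that two quite different aromatic groups at this place read alike within the scatter, whereas the earlier steps from compound 2 exchanged a different group and rested on limits. No limit on record bears on this step, and the data give no reason for the likeness of the two groups.

On these data alone, whether other groups at this place also read alike stays open: a primary amine, a carboxylic acid or a longer chain carrying the same pyridin-4-yl ring would test it. Steps that involve the limits of compound 1 and compound 3 still give a direction at best, and their true sizes cannot be read.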